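A few compounds are considered here, and "the series" means these few. Any claim that something is new, unique, unknown or untested is made for them only; others in the source may bear on it.

Measured so far:
compound 1 `CCCCN1CCC(CCC(=O)c2cc(Cl)c(N)cc2OCc2cc(OC)cc(OC)c2)CC1` — 0.479 nM
compound 2 `CCCCCN1CCC(CCC(=O)c2cc(Cl)c(N)cc2OCc2cc(OC)cc(OC)c2)CC1` — 0.813 nM

Going by the values given here, compound 2 has the higher of the two numbers in an assay on isolated protein for binding affinity to 5-hydroxytryptamine receptor 4 (Cavia porcellus), read by radioligand binding (a higher number here means a weaker inhibitor, a lower number a stronger inhibitor), yet it sits within the scatter of compound 1: the only step seen, a 1.7-fold higher number from compound 1 to compound 2 (0.23 log units; within the scatter), is a small chain lengthening that changed nothing. Among the compounds with values here, compound 3 `COc1cc(COc2cc(N)c(Cl)cc2C(=O)CCC2CCN(CCN(C)S(C)(=O)=O)CC2)cc(OC)c1` carries a different kind of change, (methyl(methylsulfonyl)amino in place of propyl on a saturated chain carbon, two bonds along the chain from an amine nitrogen in a ring), for which no measured step exists. On these data alone, the shared core is kept and the chain length resembles compound 2, so a large loss is not expected, but the new group is untested. Compound 3 is therefore estimated at 1.5 nM (range 0.4 nM to 6 nM), a step of a 1.8-fold higher number from compound 2 to compound 3 (0.27 log units; within the scatter).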

Compound 3, inhibition constant: 0.468 nM
The estimate for compound 3 lay 3.2-fold (0.51 log units) above the measured number, within the range that was stated.
By their numbers in this assay, from the lowest: compounds 3, 1 and 2 (each within the scatter of the next).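

In this assay, methyl(methylsulfonyl)amino in place of propyl gives a 1.7-fold lower number from compound 2 to compound 3 (0.24 log units; within the scatter), and in place of ethyl it gives a 1.0-fold lower number from compound 1 to compound 3 (0.01 log units; within the scatter). So this place on the chain, until now holding only carbon chains, also tolerates a group carrying nitrogen, sulfur and oxygen atoms without leaving the scatter. No supporting measurement explains this tolerance.

The compounds shown leave open whether a carboxylic acid or a primary amine at the same place would also be tolerated. They also do not separate the part played by the methylsulfonyl group from that of the methyl on its nitrogen.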